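The source may report more compounds than this note shows. Statements on the series, on what has been measured and on what is new or still open speak of the compounds shown alone.

Three close analogues built on one shared core have been tested in a functional assay on MGC-803 cells (Homo sapiens) for inhibition, read by MTT assay, with a stated time of 72 h; a lower number here means a stronger inhibitor, a higher number a weaker inhibitor. Compound 1 `C=CC(=O)Nc1cccc(NC(=O)CSc2nc(Nc3ccccc3Cl)c3ccccc3n2)c1` gives 20700 nM, compound 2 `C=CC(=O)Nc1cccc(NC(=O)CSc2nc(Nc3ccccc3C)c3ccccc3n2)c1` gives 30200 nM, and compound 3 `C=CC(=O)Nc1cccc(NC(=O)CSc2nc(Nc3cccc(Br)c3)c3ccccc3n2)c1` gives 11900 nM, the lowest number of the three. Among these, a 1.5-fold higher number from compound 1 to compound 2 (0.16 log units; within the scatter) and a 1.7-fold lower number from compound 1 to compound 3 (0.24 log units; within the scatter) stay within the scatter, while a 2.5-fold lower number from compound 2 to compound 3 (0.40 log units; beyond the scatter) lies beyond it. Compound 4 `C=CC(=O)Nc1cccc(NC(=O)CSc2nc(Nc3ccc(F)cc3)c3ccccc3n2)c1` carries 4-fluorophenyl in place of 3-bromophenyl on a nitrogen on an aromatic ring. Among the compounds with values here, no measured step exchanges a bromine for a fluorine on this ring, and the variations seen so far shift the number only modestly in either direction. For compound 4 the expected change in this assay is a 1.5-fold higher number from compound 3 to compound 4 (0.18 log units; within the scatter), a small weakening that stays within the scatter. Compound 4 is therefore estimated at 18000 nM, with a likely range from 7000 nM to 45000 nM.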

Compound 4, half-maximal inhibitory concentration: 8290 nM
Beside the measured number, compound 4's estimate is 2.2-fold (0.34 log units) above it, within the range that was stated.
By their numbers in this assay, from the lowest: compounds 4, 3, 1 and 2 (each within the scatter of the next, the first and the last beyond it).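

In this assay the 4-fluorophenyl group on this nitrogen cannot be told apart from 3-bromophenyl, with a 1.4-fold lower number from compound 3 to compound 4 (0.16 log units; within the scatter). It does separate from both groups in the other compounds, with a 3.6-fold lower number from compound 2 to compound 4 (0.56 log units; beyond the scatter) and a 2.5-fold lower number from compound 1 to compound 4 (0.40 log units; beyond the scatter), so the 2-chlorophenyl compound now has a clear gap to a neighbour, which compound 3 did not give it. No measurement here explains these differences. The halogen and its ring position change together in this step. From the compounds shown here alone, their separate contributions stay unknown. 4-Bromophenyl and 3-fluorophenyl would pull them apart, while an amine or carboxylic acid on this ring remains unexplored.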